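Trimming One Trifluoromethyl From an Inactive Analogue

This account rests on a few compounds, and the source may have more. Where it says the series, first, only, none or still open, it means among the compounds named here.

Compound 1 `Cc1cc(=O)oc2cc(OCC(=O)c3cccc(C(F)(F)F)c3)ccc12` is a weak inhibitor in a functional assay on MCF7 cells (Homo sapiens) for antiproliferative activity, with a stated time of 96 h (a higher number here means a weaker inhibitor, a lower number a stronger inhibitor), where compound 1 gives 38400 nM. Compound 2 `O=C(COc1ccc2c(C(F)(F)F)cc(=O)oc2c1)c1cc(C(F)(F)F)cc(C(F)(F)F)c1` carries two trifluoromethyl groups on its outer ring; in this assay compound 2 is recorded only as "not active" (no number reported), so no number places it against compound 1. Compound 3 `O=C(COc1ccc2c(C(F)(F)F)cc(=O)oc2c1)c1cccc(C(F)(F)F)c1` differs from compound 2 by hydrogen in place of trifluoromethyl on an aromatic carbon. Within the data shown here, no measured step covers this change, so it is expected to shift the number at most modestly, likely within the scatter, since compound 1 itself is only weakly active at 38400 nM. Compound 3 is therefore estimated at 50000 nM, within a range from 15000 nM to 200000 nM.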

Compound 3, half-maximal inhibitory concentration: "not active" (no number reported)
Compound 3 has no reported number here, so the estimate cannot be set against anything.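

Compound 2 and compound 3 are both recorded as not active, without a number, in this assay, so no step can be read between them. Nothing further bears on this result. The compounds shown leave open whether this trifluoromethyl group affects activity at all.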